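Cytotoxicity notes on the step to compound 4

The source may hold more compounds than are shown below. What is called first, only, known or untested is meant among the compounds shown, and "the series" means these compounds.

In an ADME assay on HepG2 2.2.15 cells (Homo sapiens) for cytotoxicity, read by luminescence, with a stated time of 3 days (a lower number here means that less compound is tolerated, a higher number that more compound is tolerated), compound 3 `CN1CCN(S(=O)(=O)c2cc(C(=O)Nc3ccc(F)c(Cl)c3)ccc2F)CC(O)C1` gives 31000 nM and compound 1 `O=C(Nc1ccc(F)c(Cl)c1)c1ccc(F)c(S(=O)(=O)N2C[C@H](O)CC[C@H](O)C2)c1` gives 25500 nM (a 1.2-fold higher number from compound 1 to compound 3 (0.08 log units; within the scatter)). Compound 2 `O=C(Nc1ccc(F)c(Cl)c1)c1ccc(F)c(S(=O)(=O)N2CCCCCCC2O)c1` stands apart at 7000 nM (a 4.4-fold higher number from compound 2 to compound 3 (0.65 log units; beyond the scatter)).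

Compound 4 `CC(O)C1CCCCN(S(=O)(=O)c2cc(C(=O)Nc3ccc(F)c(Cl)c3)ccc2F)C1` carries 3-(1-hydroxyethyl)azepan-1-yl in place of 6-hydroxy-4-methyl-1,4-diazepan-1-yl on a sulfonyl sulfur. The ring of compound 2 also has 1 hetero atom, so its step (a 4.4-fold higher number from compound 2 to compound 3 (0.65 log units; beyond the scatter)) is the closest guide and points to a lower number. Compound 1 goes against this, with 1 hetero atom in its ring and a step within the scatter (a 1.2-fold higher number from compound 1 to compound 3 (0.08 log units; within the scatter)). A modest drop is therefore expected, estimated as a 3.4-fold lower number from compound 3 to compound 4 (0.54 log units; beyond the scatter) in this assay overall. For compound 4 the expected value is 9000 nM with an estimated range of 3500 nM to 22000 nM.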

Compound 4, half-maximal cytotoxic concentration: 2600 nM
For compound 4 the middle estimate is 3.5-fold (0.54 log units) above the measured one; the whole stated range lies above it.
By their numbers in this assay, from the lowest: compound 4; then compound 2; then compounds 1 and 3 (each within the scatter of the next).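

The seven-membered ring does not by itself keep the number high in this assay: 3-(1-hydroxyethyl)azepan-1-yl on the sulfonyl sulfur gives a 12-fold lower number from compound 3 to compound 4 (1.08 log units; beyond the scatter) and a 9.8-fold lower number from compound 1 to compound 4 (0.99 log units; beyond the scatter) even though all three rings are seven-membered. It also falls under the eight-membered ring, with a 2.7-fold lower number from compound 2 to compound 4 (0.43 log units; beyond the scatter) as the step, so compound 4 is now the low point of the set. Nothing measured here accounts for these steps.

The change from compound 3 swaps the ring nitrogen and the substituent together, so their shares remain unseparated. From the compounds shown here alone, whether an aminoethyl or a carboxylic acid in place of 1-hydroxyethyl would raise the number remains open.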